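Adding a Second Chloro Group to a Benzyl Purine Analogue

The source may report more compounds than this note shows. Statements on the series, on what has been measured and on what is new or still open speak of the compounds shown alone.

Of the compounds shown here, three have been tested in a functional assay on 786-0 cells (Homo sapiens) for cytotoxicity, read by sulforhodamine B assay, with a stated time of 48 h; on this read-out lower numbers stand for stronger inhibition of growth and higher numbers for weaker inhibition of growth. Compound 1 `ClCc1ccccc1Cn1cnc2c(Cl)nc(Cl)nc21` gives 1860 nM. Compound 2 `ClCc1ccccc1Cn1cnc2c(Cl)ncnc21` lacks one chloro group of compound 1; in this assay compound 2 gives 17800 nM. Compound 3 `ClCc1cccc(Cn2cnc3ncnc(Cl)c32)c1`, in which the chloromethyl group sits at a different position of the benzene ring, gives 2040 nM in this assay. Its value and that of compound 1 lie within the usual scatter of each other, while its value and that of compound 2 do not.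

Among the compounds with values here, the only measured one-place change is chloro in place of hydrogen on an aromatic carbon. Its effect is a 9.6-fold lower number from compound 2 to compound 1 (0.98 log units; beyond the scatter). Compound 3 and compound 2 share the same atoms joined differently; the difference between the two cores is not broken down here.

Compound 4 `ClCc1cccc(Cn2cnc3nc(Cl)nc(Cl)c32)c1` has not yet been measured. It differs from compound 3 by chloro in place of hydrogen on an aromatic carbon. The place described for this change is the same, word for word, as for the change from compound 2 to compound 1, so the two are the same change made on two different cores. Within the data shown here, only one earlier instance of it is known, so any forecast rests on a single step. Because compound 3 gives 2040 nM and the earlier change gave a 9.6-fold lower number from compound 2 to compound 1 (0.98 log units; beyond the scatter), a step of similar size is expected, tempered slightly since a single example may overstate what repeats: a 6.8-fold lower number from compound 3 to compound 4 (0.83 log units; beyond the scatter). Compound 4 is therefore estimated to give 300 nM in this assay, most likely between 100 nM and 900 nM.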

Compound 4, concentration for 50% growth inhibition: 1580 nM
Compound 4: middle estimate off by 5.3-fold (0.72 log units), on the low side; the whole stated range lies below it.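

In this assay, the second chloro group on the core of compound 3 gives a 1.3-fold lower number from compound 3 to compound 4 (0.11 log units; within the scatter), so on this core the added atom makes no difference that can be told apart from repeat measurement. Set beside the earlier step, the same change plainly does not carry the same size from one core to the other: the same change on two cores in this assay, a 9.6-fold lower number (0.98 log units; beyond the scatter) from compound 2 to compound 1 and a 1.3-fold lower number (0.11 log units; within the scatter) from compound 3 to compound 4, 7.4-fold (0.87 log units) apart, beyond the scatter of two such steps. This shows that a large step seen on one core of this series cannot simply be added to a value on the other core, but it does not show what sets the two cores apart, as they differ in how their atoms are joined and that difference is not broken down into separate parts, and two instances cannot tell which of the steps is more typical of this change.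

Still open, on these data alone, is how an amine or a methoxy group would fare in place of this chloro group on each of the two cores. Also open, as far as these compounds go, is whether the gap between the two steps would persist if the chloromethyl group gave way to a plain methyl group or a longer chain.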